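Amino for chloro on the core of compound 2

This account rests on a few compounds, and the source may have more. Where it says the series, first, only, none or still open, it means among the compounds named here.

Compound 1 `ClCc1cccc(Cn2cnc3c(Cl)ncnc32)c1` gives 15100 nM in a functional assay on K562 cells (Homo sapiens) for cytotoxicity, read by sulforhodamine B assay, with a stated time of 48 h; a higher number here means a weaker inhibitor of growth, a lower number a stronger inhibitor of growth. Compound 2 `ClCc1cccc(Cn2cnc3c(Cl)nc(Cl)nc32)c1` carries a second chloro; in this assay compound 2 gives only a limit of the assay, > 100000 nM. The step of an at least 6.6-fold higher number from compound 1 to compound 2 (0.82 log units; beyond the scatter) is therefore known only as a lower bound. Compound 3 `ClCc1ccc(Cn2cnc3c(Cl)nc(Cl)nc32)cc1`, the other positional isomer of the chloromethyl group, gives 66100 nM in this assay. Compound 2 thus stands at the weak end of the three values, sitting at the limit of > 100000 nM in this assay, at which 1 of the 3 values shown sits.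

Compound 4 `Nc1nc(Cl)c2ncn(Cc3cccc(CCl)c3)c2n1` differs from compound 2 by amino in place of chloro on an aromatic carbon. Within the data shown here, no measured step exchanges these two groups; the only step at this position, an at least 6.6-fold higher number from compound 1 to compound 2 (0.82 log units; beyond the scatter), concerns chloro against hydrogen and says that the dichloro compound 2 lies beyond the limit while compound 1 does not. With compound 2 itself a limit, the size of the step to compound 4 is open in either direction. Compound 4 is expected to give about 30000 nM in this assay, within 8000 nM to 100000 nM, a step of an at least 3.3-fold lower number from compound 2 to compound 4 (0.52 log units; beyond the scatter).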

Compound 4, concentration for total growth inhibition: > 100000 nM
Compound 4: no number, only a limit (the forecaster's own chance of this, stated with the estimate: 30%); middle value at least 3.3-fold (0.52 log units) from the limit.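

At the position between two ring nitrogen atoms, amino now joins chloro at the limit of this assay, so among the compounds with the chloromethyl placement of compound 1, only the hydrogen of compound 1 gives a number. Amino in place of that hydrogen gives an at least 6.6-fold higher number from compound 1 to compound 4 (0.82 log units; beyond the scatter), and this size is a lower bound only. The step between compound 2 and compound 4 cannot be read, so chloro and amino cannot be ordered at this position, since both compounds sit at the limit: the limit of > 100000 nM in this assay, at which 2 of the 4 values shown sit.

Going by these compounds, whether a methyl group or a dimethylamino group at this position would give a number remains open. Also open, on these data alone, is how amino behaves with the chloromethyl placement of compound 3, which gives 66100 nM with chloro at this position.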